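Aromatic methyl at two places on related cores

A few compounds are considered here, and "the series" means these few. Any claim that something is new, unique, unknown or untested is made for them only; others in the source may bear on it.

Measured so far in a functional assay on HeLa cells (Homo sapiens) for inhibition, read by sulforhodamine B assay, with a stated time of 48 h; on this read-out higher numbers stand for weaker inhibition of growth and lower numbers for stronger inhibition of growth:

compound 1 `COC(=O)[C@@]1(C)CCC=C2[C@@H]1CC[C@@H](C)[C@]2(C)Cc1c[nH]c2c(Cl)cccc12`: 14000 nM
compound 2 `COC(=O)[C@@]1(C)CCC=C2[C@@H]1CC[C@@H](C)[C@]2(C)Cc1c(C)[nH]c2c(Cl)cccc12`: 17000 nM
compound 3 `COC(=O)[C@@]1(C)CC[C@@H]2C3=C1CC[C@@H](C)[C@]3(C)C[C@@H]1c3ccccc3N[C@H]21`: 19000 nM

In this assay compound 1 and compound 2 are separated by a 1.2-fold higher number from compound 1 to compound 2 (0.08 log units; within the scatter), the change being (methyl in place of hydrogen on an aromatic carbon). Compound 3 carries a different core; how the core of compound 3 differs from the core of compound 1 is not broken down here. The three numbers sit within the usual scatter of one another, so no order among them is read.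

Compound 4 `COC(=O)[C@@]1(C)CC[C@@H]2C3=C1CC[C@@H](C)[C@]3(C)C[C@@H]1c3cccc(C)c3N[C@H]21` is not yet measured. It differs from compound 3 by methyl in place of hydrogen on an aromatic carbon. This is the same kind of change as that from compound 1 to compound 2, but not the same: there the methyl enters on a five-membered aromatic ring with one nitrogen, next to the ring nitrogen and next to the ring atom that bears a large group; here it enters on a six-membered aromatic ring of carbon only, ortho to a fused ring and meta to a fused ring, within a fused or bridged system of five rings.

Within the data shown here, the only precedent for an aromatic methyl is the step of a 1.2-fold higher number from compound 1 to compound 2 (0.08 log units; within the scatter), which lies within the scatter. Because that step is a 1.2-fold higher number from compound 1 to compound 2 (0.08 log units; within the scatter), the expected step for compound 4 is a 1.1-fold higher number from compound 3 to compound 4 (0.04 log units; within the scatter), also within the scatter. The expectation rests on one step at a different place on a different core, so the range is kept wide. Compound 4 is estimated at 21000 nM, expected between 9000 nM and 50000 nM.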

Compound 4, concentration for 50% growth inhibition: 22000 nM
Estimate against measurement, compound 4: 1.0-fold (0.02 log units) below; the measured number falls inside the stated range.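

In this assay, methyl in place of hydrogen on an aromatic carbon gives a 1.2-fold higher number from compound 3 to compound 4 (0.06 log units; within the scatter), so on this second core, as on the first, the change does not move the number beyond the scatter. The two steps agree, and on this read-out the change carries from one core to the other without a detectable difference: the same change on two cores in this assay, a 1.2-fold higher number (0.08 log units; within the scatter) from compound 1 to compound 2 and a 1.2-fold higher number (0.06 log units; within the scatter) from compound 3 to compound 4, 1.0-fold (0.02 log units) apart, within the scatter of two such steps. This agreement is one of two null steps, each at a single place on its own core, so it gives no direction for the methyl and does not show that a step large enough to read would carry between the cores in the same way, or that the methyl would behave alike at other places on either core.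

Going by these compounds, the entering group in both steps is methyl, so it remains open whether a longer chain, a methoxy group, an amine or a carboxylic acid at these same places would move the number beyond the scatter on either core. The methyl ester common to all four compounds is also held constant, which leaves open how a carboxylic acid or an amide in its place would read.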